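Removing a methoxy group from a pyrazine ester of cinnamic acid

The source may hold more compounds than are shown below. What is called first, only, known or untested is meant among the compounds shown, and "the series" means these compounds.

The study concerns four esters that share a core, differing only at the aromatic ring that carries the unsaturated side chain. Compound 1 `COc1cc(/C=C/C(=O)O)ccc1OC(=O)c1nc(C)c(C)nc1C` carries a free acid and one methoxy group. In a functional assay on EA.hy 926 cells (Homo sapiens) for cytotoxicity, read by MTT assay, with stated times of 24 h and 12 h, tested at 12.5 uM (on this read-out lower numbers stand for a weaker effect and higher numbers for a stronger effect at the one concentration tested), compound 1 gives 38.7%. Compound 3 `Cc1nc(C)c(C(=O)Oc2ccc(/C=C/C(=O)O)cc2)nc1C` lacks that methoxy group, and in this assay compound 3 gives 34.2%. The change from compound 1 to compound 3 is hydrogen in place of methoxy on an aromatic carbon, and the step it made is a number 4.5 percentage points lower from compound 1 to compound 3 (within the scatter). Compound 2 `CCOC(=O)/C=C/c1cc(OC)c(OC(=O)c2nc(C)c(C)nc2C)c(OC)c1` is an ethyl ester with two methoxy groups, and in this assay compound 2 gives 96.6%, the highest of the three numbers. How the core of compound 2 differs from that of compound 1 is not broken down here.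

Compound 4 `CCOC(=O)/C=C/c1ccc(OC(=O)c2nc(C)c(C)nc2C)c(OC)c1` has not yet been measured in this assay. The change from compound 2 to compound 4 is hydrogen in place of methoxy on an aromatic carbon. It is the same kind of change as that from compound 1 to compound 3, but the surroundings differ: in compound 2 the carbon is meta to a 2-(ethoxycarbonyl)ethenyl group and meta to a methoxy group, whereas in compound 1 it is meta to a 2-carboxyethenyl group. Because the earlier step was a number 4.5 percentage points lower from compound 1 to compound 3 (within the scatter), a small step is expected here as well, written as a number 6.6 percentage points lower from compound 2 to compound 4 (within the scatter). On that basis compound 4 is estimated to give 90%, expected to fall between 72% and 100%.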

Compound 4, a percentage reported as activity, at one concentration (the size of the read-out at that concentration, not a potency): 52.4%
Compound 4: middle estimate off by 37.6 percentage points, on the high side; the measured number lies below the stated range.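

In this assay, hydrogen in place of methoxy on an aromatic carbon did not behave alike on the two cores: the same change on two cores in this assay, a number 4.5 percentage points lower (within the scatter) from compound 1 to compound 3 and a number 44.2 percentage points lower (beyond the scatter) from compound 2 to compound 4, 39.7 percentage points apart, beyond the scatter of two such steps

The small step between the two free acids therefore cannot be carried over to the ethyl esters, where the same change gave a number 44.2 percentage points lower from compound 2 to compound 4 (beyond the scatter), and the ethyl group in place of hydrogen on an oxygen next to a carbonyl group gave a further step of its own, a number 13.7 percentage points higher from compound 1 to compound 4 (beyond the scatter). The two pairs do not show whether the gap between the steps goes with the ethyl ester or with the methoxy group that remains in compound 4 but not in compound 3, and two pairs set no rule for the wider series.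

The compounds shown leave open how the same exchange would run on a longer ester chain or on an amide in place of the ethyl ester. They also leave open whether a hydroxyl group or a fluorine atom in place of the methoxy group would follow the hydrogen in this read-out, on either core.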